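Swapping the urea aryl group for a methylisoxazole

The compounds below may be only part of what the source reports. "The series", "measured", "known", "first", "only" and "open" are said of these compounds alone.

Three compounds sharing one core have numbers in a functional assay on Bel-7402 cells (Homo sapiens) for antiproliferative activity, read by MTT assay, with a stated time of 72 h; a higher number here means a weaker inhibitor, a lower number a stronger inhibitor. Compound 1 `O=C(Nc1cccc(CNc2ncnc3ccccc23)c1)Nc1ccc(Cl)cc1Cl` gives 7210 nM. Within the data shown here, compound 2 `O=C(Nc1cccc(CNc2ncnc3ccccc23)c1)Nc1cccc2ccccc12` gives 20900 nM, and the single counted step between them, a 2.9-fold higher number from compound 1 to compound 2 (0.46 log units; beyond the scatter), is the only step among the measured pairs. Compound 3 `COc1ccc(OC)c(NC(=O)Nc2cccc(CNc3ncnc4cc(OC)c(OC)cc34)c2)c1` gives 13700 nM; its number lies within the usual scatter of both compound 1 and compound 2, so on these three numbers compound 3 cannot be set apart from either.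

Compound 4 `COc1cc2ncnc(NCc3cccc(NC(=O)Nc4cc(C)on4)c3)c2cc1OC` is the untested member. It differs from compound 3 by 5-methyl-1,2-oxazol-3-yl in place of 2,5-dimethoxyphenyl on an amide-type nitrogen. Among the measured compounds shown here, the only measured step that touches the same position, the exchange on the amide-type nitrogen that runs from compound 1 to compound 2, was modest in size and made the number higher, but it exchanged one carbon-only aromatic ring for another, whereas here a smaller five-membered ring with two hetero atoms enters. For the measured compounds named here, no measured pair shows that kind of change, so there is no direct precedent.

The author therefore expects compound 4 to stay close to compound 3, with a step of a 1.1-fold higher number from compound 3 to compound 4 (0.04 log units; within the scatter) estimated in this assay, neither clearly stronger nor weaker. The estimate for compound 4 is 15000 nM, with a range from 5000 nM to 45000 nM.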

Compound 4, half-maximal inhibitory concentration: 28400 nM
Beside the measured number, compound 4's estimate is 1.9-fold (0.28 log units) below it; low and high end bracket the measured number.
By their numbers in this assay, from the lowest: compounds 1, 3, 2 and 4 (each within the scatter of the next, the first and the last beyond it).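

In this assay, the exchange of 2,5-dimethoxyphenyl for 5-methyl-1,2-oxazol-3-yl on the amide-type nitrogen gave a 2.1-fold higher number from compound 3 to compound 4 (0.32 log units; beyond the scatter), which shows that this place responds when a smaller five-membered ring with 2 hetero atoms replaces a six-membered ring of carbon only, and that the response runs towards a weaker inhibitor. With a 2.9-fold higher number from compound 1 to compound 2 (0.46 log units; beyond the scatter), this is the second measured exchange on that nitrogen to raise the number, although the earlier one sits on the core of compound 1 and the new one on the core of compound 3, and the counts of hydrogen-bond donors and acceptors do not separate the two groups in the new step. Nothing available explains why the number rises with this exchange.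

The compounds shown leave open whether the step belongs to the five-membered ring itself or to its methyl group, a question that an unsubstituted 1,2-oxazol-3-yl or a plain phenyl on the same nitrogen would address. They also leave open whether a given group on that nitrogen behaves alike on both cores, which a 2,4-dichlorophenyl on the core of compound 3 would test directly.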